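A Second Hydroxyl on the Ester Aromatic Ring

The source may report more compounds than this note shows. Statements on the series, on what has been measured and on what is new or still open speak of the compounds shown alone.

Compound 1 `COc1ccc(C2CC(=NOC(=O)c3ccccc3)CC(c3ccc(OC)cc3)N2C)cc1` gives 375000 nM in a functional assay, with a stated time of 30 min; a higher number here means a weaker inhibitor, a lower number a stronger inhibitor.
Compound 2 `COc1ccc(C2CC(=NOC(=O)c3cccc(O)c3)CC(c3ccc(OC)cc3)N2C)cc1` gives 34000 nM in this assay.
Compound 3 `COc1ccc(C2CC(=NOC(=O)c3ccc(O)cc3)CC(c3ccc(OC)cc3)N2C)cc1` gives 25000 nM in this assay.

Compound 3 has the lowest number of the three, yet its separation from compound 2 is only within the scatter, so the two cannot be ordered. Both stand well apart from compound 1: the steps of an 11-fold lower number from compound 1 to compound 2 (1.04 log units; beyond the scatter) and a 15-fold lower number from compound 1 to compound 3 (1.18 log units; beyond the scatter) are both large and in the same direction, each coming from a single hydroxy added on the aromatic ring of the ester. The step of a 1.4-fold lower number from compound 2 to compound 3 (0.13 log units; within the scatter) shows that where that hydroxy sits makes no difference beyond the scatter.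

Compound 4 `COc1ccc(C2CC(=NOC(=O)c3cc(O)cc(O)c3)CC(c3ccc(OC)cc3)N2C)cc1` carries the change (3,5-dihydroxyphenyl in place of 4-hydroxyphenyl on a carbonyl carbon). Among the measured compounds shown here, no measured pair adds a second hydroxy to a ring that already bears one, so the two large steps from compound 1 are the only guide, and they suggest the direction but not the size. A further lowering is therefore expected, smaller than the first, giving a 2.1-fold lower number from compound 3 to compound 4 (0.32 log units; beyond the scatter). Compound 4 is estimated at 12000 nM, in the range 3000 nM to 50000 nM.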

Compound 4, half-maximal inhibitory concentration: 19000 nM
Compound 4: the middle estimate sits 1.6-fold (0.20 log units) below what was measured, within the range that was stated.
By their numbers in this assay, from the lowest: compounds 4, 3 and 2 (each within the scatter of the next); then compound 1.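

On the ester aromatic ring, a second hydroxy adds nothing that can be told from the scatter in this assay: 3,5-dihydroxyphenyl in place of 4-hydroxyphenyl gives a 1.3-fold lower number from compound 3 to compound 4 (0.12 log units; within the scatter), and the same ring in place of 3-hydroxyphenyl gives a 1.8-fold lower number from compound 2 to compound 4 (0.25 log units; within the scatter). The full distance from the plain phenyl ester, a 20-fold lower number from compound 1 to compound 4 (1.30 log units; beyond the scatter), is therefore largely covered by the first hydroxy. The two hydroxy additions do not simply add up, since the same change counts for much on the plain phenyl ring and for little on a ring that already bears a hydroxy: the same change on two cores in this assay, a 15-fold lower number (1.18 log units; beyond the scatter) from compound 1 to compound 3 and a 1.8-fold lower number (0.25 log units; within the scatter) from compound 2 to compound 4, 8.4-fold (0.92 log units) apart, beyond the scatter of two such steps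

From the compounds shown here alone, whether a methoxy, an amine or a carboxylic acid on this ring would bring the same gain as the hydroxy stays open. So does whether a second hydroxy would behave the same way on a different core.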